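Acetamido in place of fluoro on compound 3

The source may report more compounds than this note shows. Statements on the series, on what has been measured and on what is new or still open speak of the compounds shown alone.

Among the measured compounds shown here, compound 3 (`CCNCC1CCN(c2c(F)c(F)c3c(=O)c(C(=O)O)cn(C4CC4)c3c2F)C1`) holds the lowest number so far in a functional assay on V79 cells (Cricetulus griseus) for cytotoxicity, read by colony formation; on this read-out higher numbers stand for weaker inhibition and lower numbers for stronger inhibition. Compound 3 gives 46 ug/mL, while compound 1 (`NC1CCN(c2c(F)c(F)c3c(=O)c(C(=O)O)cn(C4CC4)c3c2F)C1`) gives 100 ug/mL and compound 2 (`COc1c(N2CCC(N)C2)c(F)c(N)c2c(=O)c(C(=O)O)cn(C3CC3)c12`) gives 100 ug/mL.

The next structure, compound 4 (`CCNCC1CCN(c2c(F)c(NC(C)=O)c3c(=O)c(C(=O)O)cn(C4CC4)c3c2F)C1`), has acetamido in place of fluoro on an aromatic carbon. For the measured compounds named here, no measured step covers this replacement. The one available, a 2.2-fold lower number from compound 1 to compound 3 (0.34 log units; beyond the scatter), is modest and lies at a saturated ring carbon, so it offers only a rough guide to size. Compound 2 differs from compound 3 in more than one place and provides no clean comparison.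

Direction is therefore weakly supported. With compound 3 lowest of the three, a modest drift toward compound 1 at 100 ug/mL is expected in this assay, though no change beyond the scatter remains possible. The estimated change is a 1.3-fold higher number from compound 3 to compound 4 (0.12 log units; within the scatter). Compound 4 is expected at 60 ug/mL, with an estimated range of 28 ug/mL to 110 ug/mL.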

Compound 4, half-maximal inhibitory concentration: > 500 ug/mL
Compound 4 gave a limit, no number; the forecaster's own chance of this, stated with the estimate: 20%; at least 8.3-fold (0.92 log units) between middle value and limit.
By their numbers in this assay, from the lowest: compound 3; then compounds 1 and 2 (each within the scatter of the next). At a limit, above all of these: compound 4.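

In this assay, among the compounds shown here, acetamido in place of fluoro on the aromatic carbon gives an at least 10-fold higher number from compound 3 to compound 4 (1.03 log units; beyond the scatter), whereas the only earlier step, at a saturated ring carbon, was the modest 2.2-fold lower number from compound 1 to compound 3 (0.34 log units; beyond the scatter). This aromatic position, ortho to a fluoro group and para to a fluoro group, is therefore one where a single replacement moves the read-out strongly toward weaker inhibition, with the 3-((ethylamino)methyl)pyrrolidin-1-yl group unchanged. Compound 4 gives a limit and not a number, so the step has no upper bound: the limit of > 500 ug/mL in this assay, at which 1 of the 4 values shown sits.

From the compounds shown here alone, whether this shift belongs to acetamido itself or would follow any replacement of fluoro at this carbon remains open. A methyl or a hydroxyl at the same carbon, on the core of compound 3, would separate those two readings.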